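Chloro for fluoro: working notes on four compounds

This account rests on a few compounds, and the source may have more. Where it says the series, first, only, none or still open, it means among the compounds named here.

Measured so far:
Compound 1 `Nc1nc(N)nc(-c2cccc(F)c2)n1` gives 70% in a functional assay on the whole organism with Rattus norvegicus as the target, at a dose of 20 mg/kg by the intraperitoneal route; a higher number here means more inhibition at the dose given (going by the name of the read-out), a lower number less inhibition.
Compound 2 `Nc1nc(N)nc(-c2cc(Br)ccc2F)n1` gives 100% in this assay.
Compound 3 `Nc1nc(N)nc(-c2cccc(Cl)c2)n1` gives 100% in this assay.

One change is measured in full: chloro in place of fluoro on an aromatic carbon moves the read-out a number 30 percentage points higher from compound 1 to compound 3 (beyond the scatter). Compound 2 and compound 3 sit level at the digits printed, the two highest of the three numbers, within the scatter of each other; compound 1, with 70%, stands furthest from compound 2, beyond the scatter. The difference between the cores of compound 1 and compound 2 is not broken down here.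

Compound 4 `Nc1nc(N)nc(-c2cc(Br)ccc2Cl)n1` is the next member, unmeasured. It differs from compound 2 by chloro in place of fluoro on an aromatic carbon. This is the same kind of change as from compound 1 to compound 3, but not the same: there the place was meta to a group of 8 heavy atoms, here it is ortho to a group of 8 heavy atoms and para to a bromo group. Because compound 2 already gives 100%, the read-out cannot rise further, so the step expected from compound 2 to compound 4 is a number 5 percentage points lower from compound 2 to compound 4 (within the scatter), within the scatter. Compound 4 is expected at 95%, between 80% and 100%.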

Compound 4, a percentage reported as inhibition, in the whole organism at one dose (the size of the read-out at that dose, not a potency): 86%
The estimate for compound 4 lay 9 percentage points above the measured number, within the range that was stated.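

Chloro in place of fluoro on an aromatic carbon gives a number 14 percentage points lower from compound 2 to compound 4 (beyond the scatter) in this assay. In this assay the change therefore does not carry from one core to the other with a fixed size, nor even with a fixed direction: the same change on two cores in this assay, a number 30 percentage points higher (beyond the scatter) from compound 1 to compound 3 and a number 14 percentage points lower (beyond the scatter) from compound 2 to compound 4, 44 percentage points apart, beyond the scatter of two such steps

What this does not show is what separates the two steps: on the core of compound 4 the chloro group stands ortho to a group of 8 heavy atoms and para to a bromo group, and two cores cannot single out either the place or the bromo group as what matters, nor do they give a rule for a third core.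

The compounds shown leave open how the same change behaves when a methyl or methoxy group stands in place of the bromo group. They also leave open what an amine or a carboxylic acid on the same ring would do to the read-out at this dose.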